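From Compound 3 to Compound 4: One Group Exchanged

The source may report more compounds than this note shows. Statements on the series, on what has been measured and on what is new or still open speak of the compounds shown alone.

Of the compounds shown here, three sharing one core have been measured in a physicochemical assay for lipophilicity, measured as octanol-water partition, at pH 7.4; a higher number here means a more lipophilic compound, a lower number a more polar compound. Compound 1 `O=C([C@H](O)CS(=O)(=O)c1ccc2cc(Cl)ccc2c1)N1CCC(N2Cc3cccn3C2=O)CC1` gives 2.6, compound 2 `O=C([C@H](O)CS(=O)(=O)c1ccc2cc(Cl)ccc2c1)N1CCC(N2CCNC2=O)CC1` gives 1.73, and compound 3 `O=C([C@H](O)CS(=O)(=O)c1ccc2cc(Cl)ccc2c1)N1CCC(N2CCOCC2=O)CC1` gives 1.85. That places compound 3 in a lower pair, well short of the top value. The gaps read a number 0.75 log units lower from compound 1 to compound 3 (beyond the scatter) and a number 0.12 log units higher from compound 2 to compound 3 (within the scatter).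

The unmeasured compound 4 `O=C([C@H](O)CS(=O)(=O)c1ccc2cc(Cl)ccc2c1)N1CCC(N2NCCCC2=O)CC1` differs from compound 3 by a group of 7 heavy atoms (4 carbon, 2 nitrogen, 1 oxygen; one six-membered non-aromatic ring with 2 hetero atoms) in place of a group of 7 heavy atoms (4 carbon, 1 nitrogen, 2 oxygen; one six-membered non-aromatic ring with 2 hetero atoms), on a saturated ring carbon, on a saturated ring carbon. Both groups hold one six-membered non-aromatic ring with 2 hetero atoms.

Within the data shown here, the larger shifts, a number 0.87 log units lower from compound 1 to compound 2 (beyond the scatter) and the one to compound 3 above, each replaced a group of 9 heavy atoms with a smaller one, which does not happen here. The closer precedent is the exchange of one smaller group for another, which gave only the small gap between compound 2 and compound 3. No step beyond the scatter is therefore expected in this assay, and the estimated change is a number 0.15 log units lower from compound 3 to compound 4 (within the scatter). For compound 4 the estimated value is 1.7, with an expected range from 1.3 to 2.1.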

Compound 4, distribution coefficient: 1.85
Beside the measured number, compound 4's estimate is 0.15 log units below it; low and high end bracket the measured number.
By their numbers in this assay, from the lowest: compounds 2, 3 and 4 (each within the scatter of the next); then compound 1.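

In this assay, the group that enters at this saturated ring carbon keeps the six-membered non-aromatic ring with 2 hetero atoms and carries 1 hydrogen-bond donor where 3-oxomorpholin-4-yl carries none, yet the exchange gives no change at the digits printed from compound 3 to compound 4 (within the scatter) and so adds no step beyond the scatter. The same group also stays close to the five-membered 2-oxoimidazolidin-1-yl, with a number 0.12 log units higher from compound 2 to compound 4 (within the scatter), whereas a number 0.75 log units lower from compound 1 to compound 4 (beyond the scatter) leaves compound 1 alone, apart from the other three. Nothing measured here gives a reason for these steps.

The compounds shown leave open whether a carboxylic acid or an amine on this same ring carbon would stay with compounds 2, 3 and 4. They also do not separate the size of the group in compound 1 from its five-membered aromatic ring.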